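A few compounds are considered here, and "the series" means these few. Any claim that something is new, unique, unknown or untested is made for them only; others in the source may bear on it.

Compound 1, `COc1cc(/C=C/C(=O)c2cccc(N)c2)ccc1O`: 2.87 ug/mL
Compound 2, `COc1cc(/C=C/C(=O)c2cccc(NC(=O)C(C)C)c2)ccc1O`: 1.44 ug/mL
Compound 3, `CCOC(=O)C(=O)Nc1cccc(C(=O)/C=C/c2ccc(O)c(OC)c2)c1`: 13.3 ug/mL

All three were tested in a functional assay on HUVEC cells (Homo sapiens) for inhibition; a lower number here means a stronger inhibitor, a higher number a weaker inhibitor. Compound 3 stands highest of the three numbers: against compound 1 the change is a 4.6-fold higher number from compound 1 to compound 3 (0.67 log units; beyond the scatter), and against compound 2 it is a 9.2-fold higher number from compound 2 to compound 3 (0.97 log units; beyond the scatter), both beyond the scatter. Compound 1 and compound 2 lie within the scatter of each other, the step being a 2.0-fold lower number from compound 1 to compound 2 (0.30 log units; within the scatter).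

The next compound, compound 4, `COc1cc(/C=C/C(=O)c2cccc(NC(=O)c3ccc(Cl)cc3Cl)c2)ccc1O`, departs from compound 3 by a single change at the amide carbonyl:

2,4-dichlorophenyl in place of ethoxycarbonyl on a carbonyl carbon

For the measured compounds named here, two measured steps bear on this. The step from compound 2 to compound 3 shows that placing ethoxycarbonyl on that carbonyl carbon, instead of a carbon group, gave the high number of compound 3, and the step from compound 1 to compound 3 shows the same group raising the number from the free amine. Compound 4 removes the ethoxycarbonyl again and carries a carbon group, as compound 2 does. He therefore expects a lower number in this assay for compound 4, with the step of a 5.3-fold lower number from compound 3 to compound 4 (0.73 log units; beyond the scatter) estimated as a return toward the region of compound 1 and compound 2. Compound 4 is expected to give about 2.5 ug/mL, estimated between 0.8 ug/mL and 8 ug/mL.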

Compound 4, half-maximal inhibitory concentration: 0.4 ug/mL
Compound 4: middle estimate off by 6.3-fold (0.80 log units), on the high side; the measured number lies below the stated range.
By their numbers in this assay, from the lowest: compound 4; then compounds 2 and 1 (each within the scatter of the next); then compound 3.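

The carbonyl carbon on the amide nitrogen proves able to carry the number well below the region of compound 1 and compound 2, not merely back to it: replacing ethoxycarbonyl with 2,4-dichlorophenyl gives a 33-fold lower number from compound 3 to compound 4 (1.52 log units; beyond the scatter) in this assay, and replacing isopropyl with the same group gives a 3.6-fold lower number from compound 2 to compound 4 (0.56 log units; beyond the scatter). Acylating the free amine had so far given no step lowering the number beyond the scatter, since compound 2 lies within the scatter of compound 1, whereas the (2,4-dichlorophenyl)carbonyl group gives a 7.2-fold lower number from compound 1 to compound 4 (0.86 log units; beyond the scatter), although compound 3 still shows that acylation does not lower the number with every group. No measurement shown here explains why the aromatic group does this.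

The compounds shown leave open whether the lower number belongs to the aromatic ring itself or to its two chlorines, which a plain phenyl or a phenyl with a single chlorine would separate. They also leave open how a longer alkyl chain on the carbonyl carbon, or a carboxylic acid in place of the ethoxycarbonyl, would read in this assay.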